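The source may hold more compounds than are shown below. What is called first, only, known or untested is meant among the compounds shown, and "the series" means these compounds.

Measured in a functional assay on HeLa cells (Homo sapiens) for antiproliferative activity, read by sulforhodamine B assay; on this read-out higher numbers stand for weaker inhibition of growth and lower numbers for stronger inhibition of growth:
- Compound 1 `CC[C@@H]1O[C@H](COCc2ccccc2)[C@@H](OCc2ccccc2)[C@H](OCc2ccccc2)[C@H]1O` gives 19800 nM
- Compound 2 `CCCC[C@@H]1O[C@H](COCc2ccccc2)[C@@H](OCc2ccccc2)[C@H](OCc2ccccc2)[C@H]1O` gives > 50000 nM, a limit
- Compound 3 `CC(C)C[C@@H]1O[C@H](COCc2ccccc2)[C@@H](OCc2ccccc2)[C@H](OCc2ccccc2)[C@H]1O` gives > 50000 nM, a limit

Compound 3 has no exact number and stands at the limit of > 50000 nM in this assay, at which 2 of the 3 values shown sit. Compound 4 `OCCC[C@@H]1O[C@H](COCc2ccccc2)[C@@H](OCc2ccccc2)[C@H](OCc2ccccc2)[C@H]1O` differs from it by one change: 2-hydroxyethyl in place of isopropyl on a saturated chain carbon bound to a saturated ring carbon. This puts 2-hydroxyethyl in place of isopropyl on a saturated chain carbon bound to a saturated ring carbon.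

Going by the values given here, the steps that bear on this are an at least 2.5-fold higher number from compound 1 to compound 2 (0.40 log units; beyond the scatter) and an at least 2.5-fold higher number from compound 1 to compound 3 (0.40 log units; beyond the scatter), each beyond the scatter. There is also a step that the two limits leave unreadable from compound 2 to compound 3. None of these steps brings a hydrogen-bond donor to this place, so they give only a weak guide to the size of the new step. Compound 4 keeps a chain longer than that of compound 1, and so it is expected to remain weak in this assay. The step expected is an at least 1.4-fold lower number from compound 3 to compound 4 (0.15 log units; that floor lies within the scatter), a small move to a lower number at most. The estimate for compound 4 is 35000 nM, with an expected range from 12000 nM to 60000 nM.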

Compound 4, concentration for 50% growth inhibition: > 50000 nM
Compound 4: a limit, no number; the forecaster's own chance of this, stated with the estimate: 50%; middle value at least 1.4-fold (0.15 log units) from the limit.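

In this assay, compound 4 places a hydrogen-bond donor at this position, on 2-hydroxyethyl, and its value of > 50000 nM is a limit. Ending the chain in hydroxy therefore does not bring activity back to the level of compound 1: the result is an at least 2.5-fold higher number from compound 1 to compound 4 (0.40 log units; beyond the scatter). The steps among compound 2, compound 3 and compound 4 cannot be read, and all three sit at one limit: the limit of > 50000 nM in this assay, at which 3 of the 4 values shown sit.

As far as these compounds go, how far any of these three compounds lies past that limit stays open, so the hydroxy chain cannot be ranked against the chains without it. Also open, from the compounds shown here alone, is whether an amine or a carboxylic acid at the end of this chain, or a hydroxymethyl group in place of the ethyl of compound 1, would give a measurable value.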